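Cyclohexyl replacing the aminopropyl chain on the thioimidate nitrogen

The source may report more compounds than this note shows. Statements on the series, on what has been measured and on what is new or still open speak of the compounds shown alone.

Compound 2 `Cc1nc(O)c2cc(CS/C(S)=N/CCCN(C)C)ccc2n1` shows the highest of the two numbers in a functional assay on K562 cells (Homo sapiens) for cytotoxicity (a lower number here means a stronger inhibitor, a higher number a weaker inhibitor), giving 25600 nM; its nearest neighbour is compound 1 `CCN(CC)C(=S)SCc1ccc2nc(C)nc(O)c2c1`, which in this assay gives 4400 nM, a gap beyond the scatter. Compound 3 `Cc1nc(O)c2cc(CS/C(S)=N/C3CCCCC3)ccc2n1` carries cyclohexyl in place of 3-(dimethylamino)propyl on a double-bonded nitrogen. For the measured compounds named here, no measured pair isolates this change. A moderate step toward a lower number is expected for the move from compound 2 to compound 3, a 2.1-fold lower number from compound 2 to compound 3 (0.33 log units; beyond the scatter), because compound 1 gives 4400 nM without any nitrogen in its corresponding side chain. Compound 3 is thus estimated at 12000 nM, with a range from 4000 nM to 40000 nM.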

Compound 3, half-maximal inhibitory concentration: 31000 nM
For compound 3 the middle estimate is 2.6-fold (0.41 log units) below the measured one; the range from low to high includes it.
By their numbers in this assay, from the lowest: compound 1; then compounds 2 and 3 (each within the scatter of the next).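

In this assay, cyclohexyl in place of 3-(dimethylamino)propyl on a double-bonded nitrogen gives a 1.2-fold higher number from compound 2 to compound 3 (0.08 log units; within the scatter) and leaves the two groups indistinguishable at this position. In this pair, a chain ending in dimethylamino and a six-membered ring of carbon only read alike, so the amine nitrogen of that chain is not needed to keep this read-out. No measured property bears on this result.

Still open, as far as these compounds go, is whether a carboxylic acid, a phenyl ring or a much shorter group such as methyl on this nitrogen would move the number beyond the scatter.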